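The source may hold more compounds than are shown below. What is called first, only, known or untested is meant among the compounds shown, and "the series" means these compounds.

Working notes on the series. Among the measured compounds shown here, compound 2 `CN1[C@@H]2c3[nH]c4ccccc4c3C[C@H]1[C@H](C#N)N1[C@@H](CNC(=O)c3ccc4ccccc4c3)c3[nH]c4ccccc4c3C[C@@H]21` gives 4650 nM in a functional assay on MCF7 cells (Homo sapiens) for cytotoxicity, read by MTT assay, with a stated time of 72 h (on this read-out lower numbers stand for stronger inhibition and higher numbers for weaker inhibition), the higher of the two numbers measured so far. For the measured compounds named here, compound 1 `CN1[C@@H]2c3[nH]c4ccccc4c3C[C@H]1[C@H](C#N)N1[C@@H](CNC(=O)c3cccc(C(F)(F)F)c3)c3[nH]c4ccccc4c3C[C@@H]21` gives 110 nM in this assay, and the only step measured, a 42-fold higher number from compound 1 to compound 2 (1.63 log units; beyond the scatter), shows that what sits on the carbonyl carbon of the amide moves the read-out a great deal. Compound 3 `CN1[C@@H]2c3[nH]c4ccccc4c3C[C@H]1[C@H](C#N)N1[C@@H](CNC(=O)c3cc4ccccc4s3)c3[nH]c4ccccc4c3C[C@@H]21` differs from compound 2 by 1-benzothiophen-2-yl in place of naphthalen-2-yl on a carbonyl carbon. Going by the values given here, no measured step covers this exchange of one bicyclic aromatic group for another on the carbonyl carbon; the one measured step bears only in showing that the amide substituent is a sensitive place. With the bicyclic shape retained, the step of a 1.6-fold lower number from compound 2 to compound 3 (0.19 log units; within the scatter) is expected to lie within the scatter, if anything a somewhat lower number. Compound 3 is therefore estimated at 3000 nM in this assay, within a range from 700 nM to 12000 nM.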

Compound 3, half-maximal inhibitory concentration: 3180 nM
For compound 3 the middle estimate is 1.1-fold (0.03 log units) below the measured one; measured number inside the range.
By their numbers in this assay, from the lowest: compound 1; then compounds 3 and 2 (each within the scatter of the next).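

In this assay, 1-benzothiophen-2-yl in place of naphthalen-2-yl on the carbonyl carbon gives a 1.5-fold lower number from compound 2 to compound 3 (0.17 log units; within the scatter), so exchanging one bicyclic aromatic group for the other, with sulfur entering the ring, does not register at this position. The large gap to 3-(trifluoromethyl)phenyl is now seen with a second bicyclic group, as a 29-fold higher number from compound 1 to compound 3 (1.46 log units; beyond the scatter). Neither bicyclic amide comes near compound 1 in this read-out, and no evidence on the origin of this gap is available.

Still open, from the compounds shown here alone, is whether the trifluoromethyl group or the phenyl ring that carries it accounts for the low number of compound 1; plain phenyl or 3-chlorophenyl on the carbonyl carbon would separate the two. Also open, going by these compounds, is how a saturated group such as cyclohexyl would read here.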